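The source may hold more compounds than are shown below. What is called first, only, known or untested is meant among the compounds shown, and "the series" means these compounds.

In a functional assay on HL-60 cells (Homo sapiens) for antiproliferative activity, read by MTT assay, with a stated time of 24 h (on this read-out higher numbers stand for weaker inhibition and lower numbers for stronger inhibition), compound 1 (`CCCCc1oc2ccccc2c1C(=O)c1ccc(OCC(=O)NC(C)C)cc1`) gives 360 nM. Compound 2 (`CCCCc1oc2ccccc2c1C(=O)c1ccc(OCC(=O)NCc2ccccc2)cc1`) gives only a limit, > 50000 nM. Compound 3 (`CCCCc1oc2ccccc2c1C(=O)c1ccc(OCC(=O)N[C@H](C)c2ccccc2)cc1`) also gives only a limit, > 50000 nM, so it has no exact place in the series. The change to compound 4 (`CCCCc1oc2ccccc2c1C(=O)c1ccc(OCCCC(=O)N2CCOCC2)cc1`) is 2-((morpholin-4-yl)carbonyl)ethyl in place of (1-phenylethyl)carbamoyl on a saturated chain carbon bound to an oxygen on an aromatic ring. Two large steps bear on it, both beyond the scatter: an at least 130-fold higher number from compound 1 to compound 2 (2.14 log units; beyond the scatter) and an at least 130-fold higher number from compound 1 to compound 3 (2.14 log units; beyond the scatter). By contrast, a step that the two limits leave unreadable from compound 2 to compound 3 gives no usable size. Both large steps bring in a substituent with an aromatic ring on the amide-type nitrogen, and compound 4 has no such ring there. Within the data shown here, no measured compound carries the morpholin-4-yl group, so the size stays uncertain. A sizeable move towards a lower number is expected, with compound 1 at 360 nM as the only numerical reference. The expected step is an at least 12-fold lower number from compound 3 to compound 4 (1.09 log units; beyond the scatter). For compound 4 the estimated value is 4000 nM, with an expected range of 400 nM to 50000 nM.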

Compound 4, half-maximal inhibitory concentration: 34100 nM
Compound 4: middle estimate off by 8.5-fold (0.93 log units), on the low side; the range from low to high includes it.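

Taking the aromatic ring off the amide-type nitrogen does not by itself return the series to the level of the isopropyl amide in this assay: a 95-fold higher number from compound 1 to compound 4 (1.98 log units; beyond the scatter). Against the two aromatic amides, only a floor within the scatter can be read: an at least 1.4-fold lower number from compound 3 to compound 4 (0.16 log units; that floor lies within the scatter), and an at least 1.4-fold lower number from compound 2 to compound 4 (0.16 log units; that floor lies within the scatter). Both of these steps start from a limit and not from a number: the limit of > 50000 nM in this assay, at which 2 of the 4 values shown sit.

Compound 4 leaves open whether the higher number follows the morpholin-4-yl group or the chain carrying it. Also open, on these data alone, is whether a cyclopropyl or tert-butyl group on the amide-type nitrogen would hold the level of compound 1.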